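The source may report more compounds than this note shows. Statements on the series, on what has been measured and on what is new or still open speak of the compounds shown alone.

Measured so far:
Compound 1, `c1cncc(-c2ccccc2OCC2=NCCN2)c1`: 79.4 nM
Compound 2, `c1ccc(-c2cnccn2)c(OCC2=NCCN2)c1`: 631 nM
Compound 3, `c1ccc(-c2cc[nH]n2)c(OCC2=NCCN2)c1`: 79.4 nM

These three compounds share one core and differ only in the aromatic group attached to it; all were tested in a functional assay for activation of Alpha-1B adrenergic receptor (Homo sapiens), read by calcium flux; a higher number here means that more compound is needed for the effect, a lower number that less compound is needed. Compound 1 gives 79.4 nM, the same number as compound 3, which gives 79.4 nM; together these two are the lowest of the three. Compound 2 is the furthest away, a 7.9-fold higher number from compound 1 to compound 2 (0.90 log units; beyond the scatter). Between compound 1 and compound 3 there is no change at the digits printed from compound 1 to compound 3 (within the scatter).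

Compound 4, `c1ccc(-c2ccns2)c(OCC2=NCCN2)c1`, has not yet been measured. It differs from compound 1 in one place: 1,2-thiazol-5-yl in place of pyridin-3-yl on an aromatic carbon. For the measured compounds named here, two measured steps bear on this change. Replacing pyridin-3-yl with another six-membered ring, pyrazin-2-yl, gave a 7.9-fold higher number from compound 1 to compound 2 (0.90 log units; beyond the scatter); replacing it with a five-membered ring, 1H-pyrazol-3-yl, gave no change at the digits printed from compound 1 to compound 3 (within the scatter). The entering 1,2-thiazol-5-yl is, like the pyrazolyl group, a five-membered aromatic ring with two hetero atoms, so compound 3 is the nearer precedent, not compound 2. The expected step is therefore small, a 1.3-fold higher number from compound 1 to compound 4 (0.10 log units; within the scatter), with no direction that should stand out beyond the scatter. Compound 4 is estimated at 100 nM, within a range from 30 nM to 400 nM.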

Compound 4, half-maximal effective concentration: 12.6 nM
For compound 4 the middle estimate is 7.9-fold (0.90 log units) above the measured one; measured number outside the range, below it.
By their numbers in this assay, from the lowest: compound 4; then compounds 1 and 3 (each within the scatter of the next); then compound 2.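

In this assay, the group on this aromatic carbon can do more than hold the number level or raise it: 1,2-thiazol-5-yl in place of pyridin-3-yl gives a 6.3-fold lower number from compound 1 to compound 4 (0.80 log units; beyond the scatter), whereas neither earlier change went below compound 1. Ring size and hetero atom count do not settle the outcome, since 1H-pyrazol-3-yl and 1,2-thiazol-5-yl are both five-membered aromatic rings with two hetero atoms, yet exchanging them gives a 6.3-fold lower number from compound 3 to compound 4 (0.80 log units; beyond the scatter). The span at this one position also widens, with a 50-fold lower number from compound 2 to compound 4 (1.70 log units; beyond the scatter), so the choice of aromatic group here can carry a large change in the number, but no supporting data are available to explain any of these differences.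

The compounds shown cannot separate the part played by the sulfur from that of the ring as a whole; thiophen-2-yl, which has sulfur but no ring nitrogen, and 1,2-oxazol-5-yl, which has oxygen in place of sulfur, would bear directly on that. As far as these compounds go, it also remains open how this position responds to something other than an aromatic ring, such as an amine or a carboxylic acid.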